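This account rests on a few compounds, and the source may have more. Where it says the series, first, only, none or still open, it means among the compounds named here.

Measured compounds in an ADME assay on a cell-free system (plasma, Rattus norvegicus) for metabolic stability, read by LC-MS, with a stated time of 60 min, at 37 degrees C, tested at 50 uM; a lower number here means that less of the compound is left, a higher number that more of the compound is left:
compound 1, `Cc1oc(=O)oc1COC(=O)C1=C(S[C@@H]2CN[C@H](C(=O)Nc3cccc(C(=O)OCc4oc(=O)oc4C)c3)C2)[C@H](C)[C@@H]2[C@@H]([C@@H](C)O)C(=O)N12`, gives 0%
compound 2, `C[C@@H](O)[C@H]1C(=O)N2C(C(=O)OCOC(=O)C(C)(C)C)=C(S[C@@H]3CN[C@H](C(=O)Nc4cccc(C(=O)O)c4)C3)[C@H](C)[C@H]12`, gives 0%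
compound 3, `C[C@@H](O)[C@H]1C(=O)N2C(C(=O)OCOC(=O)OC(C)(C)C)=C(S[C@@H]3CN[C@H](C(=O)Nc4cccc(C(=O)O)c4)C3)[C@H](C)[C@H]12`, gives 0%

Compound 3 stands level with compounds 1 and 2 at the digits shown; in each case none of the compound is found after the incubation. Going by the values given here, the only measured step at the position in question is no change at the digits printed from compound 2 to compound 3 (within the scatter), which showed no change within the scatter. Compound 4, `C[C@@H](O)[C@H]1C(=O)N2C(C(=O)OCOC(=O)OC3CCCCC3)=C(S[C@@H]3CN[C@H](C(=O)Nc4cccc(C(=O)O)c4)C3)[C@H](C)[C@H]12`, differs from compound 3 by cyclohexyl in place of tert-butyl on an oxygen next to a carbonyl group. Because compound 3 gives 0% and the step of no change at the digits printed from compound 2 to compound 3 (within the scatter) at this very place moved nothing, the expected step of no change at the digits printed from compound 3 to compound 4 (within the scatter) is none beyond the scatter. Compound 4 is therefore estimated at 0%, with a range from 0% to 10%.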

Compound 4, percent of the compound remaining: 0%
Compound 4: middle estimate and measured number agree at the digits printed; low and high end bracket the measured number.
By their numbers in this assay, from the lowest: compounds 1, 2, 3 and 4 (each within the scatter of the next).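

Cyclohexyl in place of tert-butyl on an oxygen next to a carbonyl group gives no change at the digits printed from compound 3 to compound 4 (within the scatter) in this assay, and cyclohexyloxy in place of tert-butyl on a carbonyl carbon gives no change at the digits printed from compound 2 to compound 4 (within the scatter) as well. At this position, then, a group with a six-membered non-aromatic ring of carbon only reads the same as the ringless tert-butyl. Nothing measured here bears on why this is so.

As far as these compounds go, it remains open whether a longer chain ending in an amine at this place would leave any compound after the incubation in this assay at all. With every reading alike, the compounds also do not tell how quickly each one is lost.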